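From Methoxy to Chloro on a Phenyl Ring

The compounds below may be only part of what the source reports. "The series", "measured", "known", "first", "only" and "open" are said of these compounds alone.

Two close relatives set the scene. Compound 1 `NS(=O)(=O)NCC1CCN(c2cc(-c3ccccc3)ncn2)CC1` carries a plain phenyl ring on the shared core. In a functional assay on SK-BR-3 cells (Homo sapiens) for antiproliferative activity (on this read-out higher numbers stand for weaker inhibition of growth and lower numbers for stronger inhibition of growth), compound 1 gives > 100000 nM, which is a limit of the assay rather than a number. Compound 2 `COc1ccccc1-c1cc(N2CCC(CNS(N)(=O)=O)CC2)ncn1` differs only by a methoxy in place of hydrogen on an aromatic carbon. In this assay compound 2 gives > 100000 nM, again a limit of the assay. The step that the two limits leave unreadable from compound 1 to compound 2 therefore cannot be read, since both ends sit at the limit of > 100000 nM in this assay, at which 2 of the 2 values shown sit. Compound 2 thus stands at the limit, with no finite number to place it against another compound.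

Compound 3 `NS(=O)(=O)NCC1CCN(c2cc(-c3ccccc3Cl)ncn2)CC1` is the next variation: chloro in place of methoxy on an aromatic carbon. Only the unreadable step from phenyl to methoxyphenyl bears on it, and it fixes neither direction nor size. With both measured relatives at the limit, no shift beyond the scatter can be argued for in this assay. Compound 3 is therefore expected to give 150000 nM, within a range from 30000 nM to 800000 nM. That amounts to an expected step that the limit leaves unreadable from compound 2 to compound 3, most likely reported once more as a limit.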

Compound 3, concentration for 50% growth inhibition: > 100000 nM
Compound 3: no number, only a limit (the forecaster's own chance of this, stated with the estimate: 80%); the middle value is on the limit's open side.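

Compound 1, compound 2 and compound 3 all end at a limit in this assay, so no step among them can be read: the limit of > 100000 nM in this assay, at which 3 of the 3 values shown sit.

The compounds shown leave open whether hydrogen, methoxy and chloro on the phenyl ring differ at all in their inhibition of growth, as they offer no finite number to compare.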